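Substituents on the ether oxygen of a fluorinated cyclopropane core

The source may hold more compounds than are shown below. What is called first, only, known or untested is meant among the compounds shown, and "the series" means these compounds.

Compound 1 `CO[C@@H]1C[C@@H]2[C@H]([C@]1(N)C(=O)O)[C@@]2(F)C(=O)O` is the parent of this small set. In an assay on CHO cells for binding affinity to metabotropic glutamate receptor 2 (Rattus norvegicus) (on this read-out higher numbers stand for weaker inhibition and lower numbers for stronger inhibition), compound 1 gives 39.2 nM, the highest of the three numbers measured; the nearest to it is compound 2 `N[C@]1(C(=O)O)[C@H]2[C@@H](C[C@H]1OCCCc1ccccc1)[C@]2(F)C(=O)O`, which in this assay gives 9.83 nM, and the furthest is compound 3 `N[C@]1(C(=O)O)[C@H]2[C@@H](C[C@H]1OCc1cccc(F)c1F)[C@]2(F)C(=O)O`, which in this assay gives 4.25 nM. The two steps from the parent both lower the number: a 4.0-fold lower number from compound 1 to compound 2 (0.60 log units; beyond the scatter), and a 9.2-fold lower number from compound 1 to compound 3 (0.96 log units; beyond the scatter). Between the two substituted ethers the step is a 2.3-fold lower number from compound 2 to compound 3 (0.36 log units; beyond the scatter).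

Compound 4 `N[C@]1(C(=O)O)[C@H]2[C@@H](C[C@H]1OCc1c(F)cccc1F)[C@]2(F)C(=O)O` differs from compound 1 as follows: 2,6-difluorophenyl in place of hydrogen on a saturated chain carbon bound to an oxygen on a saturated carbon. Going by the values given here, the steps that bear on it are those from compound 1 to its two substituted analogues, and the closer comparison is compound 3, whose group is likewise a difluorophenyl. A lowering of the number of modest size, similar to the step to compound 3, is therefore expected, so that a 6.5-fold lower number from compound 1 to compound 4 (0.82 log units; beyond the scatter). Compound 4 is estimated to give 6 nM, expected to lie between 2.5 nM and 15 nM.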

Compound 4, inhibition constant: 7.02 nM
The estimate for compound 4 lay 1.2-fold (0.07 log units) below the measured number; the range from low to high includes it.
By their numbers in this assay, from the lowest: compounds 3, 4 and 2 (each within the scatter of the next, the first and the last beyond it); then compound 1.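

In this assay, 2,6-difluorophenyl in place of hydrogen on the saturated chain carbon bound to the ether oxygen gives a 5.6-fold lower number from compound 1 to compound 4 (0.75 log units; beyond the scatter), so a second difluorophenyl group also stands beyond the scatter from the parent. The two difluorophenyl groups cannot be told apart in this measurement, with a 1.7-fold higher number from compound 3 to compound 4 (0.22 log units; within the scatter), and neither can 2,6-difluorophenyl and phenethyl, with a 1.4-fold lower number from compound 2 to compound 4 (0.15 log units; within the scatter), even though the step from compound 2 to compound 3 lies beyond the scatter. No measurement available here accounts for these numbers.

The compounds shown leave open how an unsubstituted phenyl or a phenyl with a single fluorine would compare at this position. They also leave open what a chain ending in an amine or a carboxylic acid, or a chain longer than phenethyl, would do to the number.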